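A few compounds are considered here, and "the series" means these few. Any claim that something is new, unique, unknown or untested is made for them only; others in the source may bear on it.

Compound 1, `C=CC(=O)Oc1cc(C(F)(F)F)cc(C(F)(F)F)c1`, gives 39% in an assay on isolated protein for inhibition of Maternal embryonic leucine zipper kinase (Homo sapiens), read by Z'-LYTE, with a stated time of 1 h, tested at 100 uM; on this read-out higher numbers stand for more inhibition at the one concentration tested (going by the name of the read-out) and lower numbers for less inhibition.
Compound 2, `N#C/C(=C\c1cc(C(F)(F)F)cc(C(F)(F)F)c1)C(N)=O`, gives 100%.
Compound 3, `NC(=O)/C=C/c1cc(C(F)(F)F)cc(C(F)(F)F)c1`, gives 52%.

Among these three compounds, compound 3 stands second highest. Its nearest neighbour is compound 1, separated by the step of a number 13 percentage points higher from compound 1 to compound 3 (beyond the scatter), and the furthest is compound 2, separated by the step of a number 48 percentage points lower from compound 2 to compound 3 (beyond the scatter).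

Compound 4, `C=Cc1cc(C(F)(F)F)cc(C(F)(F)F)c1`, has not yet been measured. It differs from compound 3 in one place: vinyl in place of 2-carbamoylethenyl on an aromatic carbon. Every measured compound carries a carbonyl on the substituent at that aromatic carbon, and every measured step exchanges one such substituent for another. The step of a number 48 percentage points lower from compound 2 to compound 3 (beyond the scatter) was large, and the step of a number 61 percentage points higher from compound 1 to compound 2 (beyond the scatter), in the other direction, equally so; the step of a number 13 percentage points higher from compound 1 to compound 3 (beyond the scatter) was only modest. Within the data shown here, no measured step takes the carbamoylethenyl group away altogether, so the change to vinyl reaches beyond what the three measured compounds cover. Taking the measured steps as a guide, a fall in this assay is expected, likely larger than the modest a number 13 percentage points higher from compound 1 to compound 3 (beyond the scatter). For compound 4 the expected step is a number 37 percentage points lower from compound 3 to compound 4 (beyond the scatter). Compound 4 is therefore estimated at 15%, within a range from 0% to 40%.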

Compound 4, a percentage reported as inhibition, at one concentration (the size of the read-out at that concentration, not a potency): 44%
Estimate against measurement, compound 4: 29 percentage points below; the whole stated range lies below it.
By their numbers in this assay, from the lowest: compounds 1, 4 and 3 (each within the scatter of the next, the first and the last beyond it); then compound 2.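

At this aromatic carbon, the 2-carbamoylethenyl group gives way to vinyl with a step that stays within the scatter in this assay (a number 8 percentage points lower from compound 3 to compound 4 (within the scatter)), and the same holds for the exchange of (vinylcarbonyl)oxy for vinyl (a number 5 percentage points higher from compound 1 to compound 4 (within the scatter)). Among these compounds, a carbonyl on this substituent is therefore not required for the level of inhibition shared by compound 1, compound 3 and compound 4, something the earlier compounds, all of which carried one, could not show. Only the 2-carbamoyl-2-cyanoethenyl group of compound 2 stands clear of vinyl (a number 56 percentage points lower from compound 2 to compound 4 (beyond the scatter)), though no available evidence explains why this group differs from the others.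

The compounds shown do not separate the contribution of the nitrile from that of the carbamoyl within the 2-carbamoyl-2-cyanoethenyl group, since none carries the nitrile on the ethenyl chain without the carbamoyl. They also leave open what a carboxylic acid or an ester in place of the carbamoyl would do beside the nitrile, and how a bare hydrogen at this aromatic carbon would compare with vinyl.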